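Ethylamino analogue of compound 2: notes on the series

The source may hold more compounds than are shown below. What is called first, only, known or untested is meant among the compounds shown, and "the series" means these compounds.

In a functional assay on HeLa cells (Homo sapiens) for antiproliferative activity, read by MTT assay, with a stated time of 48 h (a lower number here means a stronger inhibitor, a higher number a weaker inhibitor), compound 1 (`COc1ccc(C(=O)c2ccc(OC)c3c2C=CC(C)(C)O3)c(NC(=O)CN)c1`) gives 100 nM. Among the measured compounds shown here, compound 2 (`CNCC(=O)Nc1cc(OC)ccc1C(=O)c1ccc(OC)c2c1C=CC(C)(C)O2`) gives 2170 nM, the higher of the two numbers so far and so the weaker inhibitor of the pair. Compound 3 (`CCNCC(=O)Nc1cc(OC)ccc1C(=O)c1ccc(OC)c2c1C=CC(C)(C)O2`) is not yet measured. It differs from compound 2 by methyl in place of hydrogen on a saturated chain carbon bound to an amine nitrogen, turning methylamino into ethylamino. For the measured compounds named here, one measured step bears on this, and it is a related change rather than the same one: a 22-fold higher number from compound 1 to compound 2 (1.34 log units; beyond the scatter), large and beyond the scatter, with methyl in place of hydrogen on an amine nitrogen. Going by the values given here, no methyl to ethyl pair has been measured, and a single step sets no trend. On the evidence of that step to compound 2, a further rise in this assay is expected, though much smaller and possibly not clear of the scatter. The estimated step is a 1.4-fold higher number from compound 2 to compound 3 (0.14 log units; within the scatter). For compound 3 the expected value is 3000 nM, within an estimated range from 1000 nM to 9000 nM.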

Compound 3, half-maximal inhibitory concentration: 4270 nM
Estimate against measurement, compound 3: 1.4-fold (0.15 log units) below, and the stated range covers the measured number.
By their numbers in this assay, from the lowest: compound 1; then compounds 2 and 3 (each within the scatter of the next).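

Under this assay the change from methylamino to ethylamino, methyl in place of hydrogen on a saturated chain carbon bound to an amine nitrogen, gives a step that stays within the scatter (a 2.0-fold higher number from compound 2 to compound 3 (0.29 log units; within the scatter)), so this change does not separate the two compounds in this assay. An ethyl group on that amine, set against none at all, is a large step (a 43-fold higher number from compound 1 to compound 3 (1.63 log units; beyond the scatter)), and together with the earlier methyl step (a 22-fold higher number from compound 1 to compound 2 (1.34 log units; beyond the scatter)) it shows that, among these three compounds, both substituted amines stand well apart from the unsubstituted amino group of compound 1, while methyl and ethyl cannot be told apart. Nothing on hand accounts for either step.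

On these data alone, whether a propyl group or a longer chain on the same nitrogen stays with compound 2 and compound 3 or moves clear of them remains open. Also open, as far as these compounds go, is how a dimethylamino group, or a ring amine such as pyrrolidine in that place, would stand against compound 1 (100 nM).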